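A Second Methoxy Group on a Shared Core

This account rests on a few compounds, and the source may have more. Where it says the series, first, only, none or still open, it means among the compounds named here.

Compound 1, `O=C1N/C(=N/c2csc(-c3ccc(Cl)cc3)c2)S/C1=C\c1ccccc1`: > 50000 nM
Compound 2, `COc1ccc(/C=C2\S/C(=N\c3csc(-c4ccc(Cl)cc4)c3)NC2=O)cc1`: 28100 nM
Compound 3, `COc1cccc(N2C(=O)CS/C2=N\c2csc(-c3ccc(Cl)cc3)c2)c1`: 33000 nM

Of the compounds shown here, three have been measured in a functional assay on SW-620 cells (Homo sapiens) for cytotoxicity, read by MTT assay, with a stated time of 72 h; a lower number here means a stronger inhibitor, a higher number a weaker inhibitor. For compound 1 the result is a limit rather than a number: in this assay compound 1 gives > 50000 nM, which is the limit of > 50000 nM in this assay, at which 1 of the 3 values shown sits. Compound 2 gives 28100 nM and compound 3 gives 33000 nM, and these two values lie within the scatter of each other. Compounds 1 and 2 differ in one place, (methoxy in place of hydrogen on an aromatic carbon), and that change brought an at least 1.7-fold lower number from compound 1 to compound 2 (0.25 log units; that floor lies within the scatter). The difference between the core of compound 1 and the core of compound 3 is not broken down here.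

Compound 4, `COc1ccc(N2C(=O)CS/C2=N\c2csc(-c3ccc(Cl)cc3)c2)cc1OC`, has not yet been measured. It differs from compound 3 by methoxy in place of hydrogen on an aromatic carbon. This is the same kind of change as from compound 1 to compound 2, though not the same: here the place is also ortho to a methoxy group. The earlier step rests on a limit and lies within the scatter, so only a modest step is expected here, a 1.7-fold lower number from compound 3 to compound 4 (0.22 log units; within the scatter), resting on an at least 1.7-fold lower number from compound 1 to compound 2 (0.25 log units; that floor lies within the scatter). Compound 4 is therefore expected to give about 20000 nM.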

Compound 4, half-maximal inhibitory concentration: > 50000 nM
Compound 4: a limit, no number; the forecaster's own chance of this, stated with the estimate: 15%; middle value at least 2.5-fold (0.39 log units) from the limit.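

In this assay compound 4 gives > 50000 nM, which is a limit and not a number. Putting a methoxy group in place of hydrogen on the aromatic ring gave an at least 1.5-fold higher number from compound 3 to compound 4 (0.18 log units; that floor lies within the scatter), so in this series the change cannot simply be carried from one core to the other and be expected to act in the same way: the same change on two cores in this assay, an at least 1.7-fold lower number (0.25 log units; that floor lies within the scatter) from compound 1 to compound 2 and an at least 1.5-fold higher number (0.18 log units; that floor lies within the scatter) from compound 3 to compound 4, at least 2.6-fold (0.43 log units) apart, beyond the scatter of two such steps This does not show the true size of either step, nor whether the core itself or the place of the new group, ortho to a methoxy group and para to a large group, accounts for the gap, since each step has a limit at one end: the limit of > 50000 nM in this assay, at which 2 of the 4 values shown sit.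

The compounds shown leave open whether this result belongs to methoxy in particular or to any group at this place on the core of compound 3. A hydroxyl group, an amine or a carboxylic acid at the same place would be a direct way to test this.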